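Replacing the thiophene arm with a naphthalene arm

The source may hold more compounds than are shown below. What is called first, only, known or untested is meant among the compounds shown, and "the series" means these compounds.

Of the compounds shown here, three sharing one core have been measured in a functional assay on A549 cells (Homo sapiens) for antiproliferative activity, read by MTT assay, with a stated time of 48 h; on this read-out lower numbers stand for stronger inhibition and higher numbers for weaker inhibition. Compound 1 `O=C(/C=C/c1ccccc1Cl)Nc1ccc2ncnc(Nc3cccc(Cl)c3)c2c1` gives 4.58 ug/mL. Compound 2 `O=C(/C=C/c1ccccc1Br)Nc1ccc2ncnc(Nc3cccc(Cl)c3)c2c1` gives 5.63 ug/mL. Compound 3 `O=C(/C=C/c1cccs1)Nc1ccc2ncnc(Nc3cccc(Cl)c3)c2c1` gives 9.23 ug/mL, the highest of the three numbers, yet the steps of a 2.0-fold higher number from compound 1 to compound 3 (0.30 log units; within the scatter) and a 1.6-fold higher number from compound 2 to compound 3 (0.21 log units; within the scatter) both stay within the scatter, as does a 1.2-fold higher number from compound 1 to compound 2 (0.09 log units; within the scatter). Compound 4 `O=C(/C=C/c1cccc2ccccc12)Nc1ccc2ncnc(Nc3cccc(Cl)c3)c2c1` has not yet been measured. It differs from compound 3 in one place: naphthalen-1-yl in place of thiophen-2-yl on a double-bonded chain carbon bound to a double-bonded chain carbon. The two steps that bear on this change, the swaps of the aryl group at the same place from compound 1 and from compound 2 to compound 3, were each within the scatter, so the data give no ground to expect a step beyond the scatter in this assay for this further aryl swap. The step from compound 3 to compound 4 is therefore estimated as a 1.4-fold lower number from compound 3 to compound 4 (0.15 log units; within the scatter). Compound 4 is expected to give about 6.5 ug/mL, somewhere between 2.5 ug/mL and 17 ug/mL.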

Compound 4, half-maximal inhibitory concentration: 1.49 ug/mL
The estimate for compound 4 lay 4.4-fold (0.64 log units) above the measured number; measured number below the stated range.
By their numbers in this assay, from the lowest: compound 4; then compounds 1, 2 and 3 (each within the scatter of the next).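

In this assay, this position turns out to respond to the choice of aryl group: the swaps among the earlier arms stayed within the scatter, whereas naphthalen-1-yl gives a 6.2-fold lower number from compound 3 to compound 4 (0.79 log units; beyond the scatter). The same arm also gives a 3.8-fold lower number from compound 2 to compound 4 (0.58 log units; beyond the scatter) and a 3.1-fold lower number from compound 1 to compound 4 (0.49 log units; beyond the scatter), so compound 4 has the lowest number of the four, and its step is beyond the scatter from each of the earlier arms. Nothing available here explains this drop in the number.

The compounds shown leave open whether any gain needs both aromatic rings of naphthalen-1-yl, which an unsubstituted phenyl group at the same place would help to test. They also leave open whether the low number would survive an amine or a carboxylic acid placed on the naphthalene arm.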